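Pyrazolyl in place of the bicyclic azaheteroaryl on the acetyl arm

The source may hold more compounds than are shown below. What is called first, only, known or untested is meant among the compounds shown, and "the series" means these compounds.

Measured compounds:
compound 1, `C[C@@H]1CN(c2sc(CO)nc2-c2nc3ccccc3[nH]2)CCN1C(=O)Cn1cnc2cccnc21`, 3380 nM
compound 2, `CCOc1ncc(-c2nc(C(F)(F)F)sc2N2CCN(C(=O)Cn3ccc4cccnc43)[C@H](C)C2)cn1`, 47 nM
compound 3, `CCOc1ncc(-c2nc(C(F)(F)F)sc2N2CCN(C(=O)Cn3ccc4cnccc43)[C@H](C)C2)cn1`, 25 nM

In an assay on blood for inhibition of C-X-C chemokine receptor type 3 (Homo sapiens), with a stated time of 30 min (a higher number here means a weaker inhibitor, a lower number a stronger inhibitor), compound 3 gives 25 nM, the lowest of the three numbers. Its nearest neighbour is compound 2, and the step of a 1.9-fold lower number from compound 2 to compound 3 (0.27 log units; within the scatter) lies within the scatter, so the two cannot be ordered. Going by the values given here, no single-place step connects compound 3 to compound 1, which differs from it in several places. In this assay compound 1 gives 3380 nM, a much higher number.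

Compound 4 is `CCOc1ncc(-c2nc(C(F)(F)F)sc2N2CCN(C(=O)Cn3nccc3C)[C@H](C)C2)cn1`. It differs from compound 3 by a group of 6 heavy atoms (4 carbon, 2 nitrogen; one five-membered aromatic ring with 2 hetero atoms) in place of a group of 9 heavy atoms (7 carbon, 2 nitrogen; one five-membered aromatic ring with 1 hetero atom, one six-membered aromatic ring with 1 hetero atom), on a saturated chain carbon bound to a carbonyl carbon. Among the compounds with values here, the one measured step at this position, a 1.9-fold lower number from compound 2 to compound 3 (0.27 log units; within the scatter), exchanged one bicyclic group for another of the same size and moved the number by less than the scatter. Within the data shown here, no measured step covers the loss of the six-membered ring. On this weak base, compound 4 is expected to show the step of a 3.2-fold higher number from compound 3 to compound 4 (0.51 log units; beyond the scatter), with a wide range. In this assay compound 4 is estimated at 80 nM, between 20 nM and 400 nM.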

Compound 4, half-maximal inhibitory concentration: 289 nM
Estimate against measurement, compound 4: 3.6-fold (0.56 log units) below, within the range that was stated.
By their numbers in this assay, from the lowest: compounds 3 and 2 (each within the scatter of the next); then compound 4; then compound 1.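

In this assay, the bicyclic groups on the saturated chain carbon bound to a carbonyl carbon cannot be ordered against each other, but 5-methyl-1H-pyrazol-1-yl separates from both, with a 12-fold higher number from compound 3 to compound 4 (1.06 log units; beyond the scatter) and a 6.1-fold higher number from compound 2 to compound 4 (0.79 log units; beyond the scatter). Going by these compounds alone, this is the first change at this position to go beyond the scatter, and it shows that the number here responds to the group as a whole, not only to a swap between bicyclic groups of the same size. The change still bundles the loss of the six-membered ring with a second ring nitrogen and a methyl group, so the step cannot be assigned to any one of these.

Open, as far as these compounds go, is whether an unsubstituted pyrazolyl or a phenyl ring on the same carbon would give a number nearer that of compound 3 or compound 4. Nothing on hand explains the size of the step.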